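Cytotoxicity of Three Amide Analogues: Estimating Compound 3

The source may hold more compounds than are shown below. What is called first, only, known or untested is meant among the compounds shown, and "the series" means these compounds.

Measured so far in an ADME assay on CEM-SS cells (Homo sapiens) for cytotoxicity, read by XTT assay, with a stated time of 6 days; on this read-out lower numbers stand for higher toxicity in this test and higher numbers for lower toxicity in this test:
compound 1 `CCCC(=O)OCSc1ccccc1C(=O)NCCCNC(C)=O` gives 21.1 uM
compound 2 `CCCC(=O)OCSc1ccccc1C(=O)N[C@@H]1CCC[C@H]1C(N)=O` gives 43.7 uM

Within the data shown here, compound 2 stands highest of the two numbers in this assay; its nearest neighbour is compound 1, and the single measured step is a 2.1-fold higher number from compound 1 to compound 2 (0.32 log units; beyond the scatter). Compound 3 `CCCC(=O)OCSc1ccccc1C(=O)NCC(=O)NC(C)(C)C` has not yet been measured. It differs from compound 2 in one place: ((tert-butyl)carbamoyl)methyl in place of 2-carbamoylcyclopentyl on an amide-type nitrogen.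

Among the measured compounds shown here, the only step that bears on this change is a 2.1-fold higher number from compound 1 to compound 2 (0.32 log units; beyond the scatter), which also exchanged one group for another on the same amide-type nitrogen and was modest in size. The group entering in compound 3 has no ring, as was the case for the 3-acetamidopropyl group of compound 1, whereas the group leaving compound 2 carries a five-membered non-aromatic ring. A step of roughly similar size, running back toward the number of compound 1, is therefore the most reasonable expectation, though a step within the scatter cannot be excluded on two data points. Compound 3 is estimated at 30 uM, with a range from 13 uM to 70 uM. The expected step is thus a 1.5-fold lower number from compound 2 to compound 3 (0.16 log units; within the scatter).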

Compound 3, half-maximal toxic concentration: 46.8 uM
Beside the measured number, compound 3's estimate is 1.6-fold (0.19 log units) below it; the range from low to high includes it.
By their numbers in this assay, from the lowest: compound 1; then compounds 2 and 3 (each within the scatter of the next).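

In this assay, exchanging the 2-carbamoylcyclopentyl group, with its five-membered ring and two defined stereocentres, for the ring-free ((tert-butyl)carbamoyl)methyl group on the amide-type nitrogen gives a 1.1-fold higher number from compound 2 to compound 3 (0.03 log units; within the scatter), so among these compounds neither the ring nor the stereocentres are needed to keep the number where compound 2 has it. Having no ring also does not place a compound with compound 1, since the change from the 2-acetamidoethyl group to the (tert-butyl)carbamoyl group on the saturated chain carbon bound to that nitrogen gives a 2.2-fold higher number from compound 1 to compound 3 (0.35 log units; beyond the scatter), a modest move toward lower toxicity in this test that depends on the end of the chain and not on the presence of a ring. No measurement offered here accounts for why these groups give the numbers they do.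

The compounds shown leave open whether a chain ending in an amine or a carboxylic acid on this nitrogen would stay with compound 2 and compound 3 or move away from them. They also leave open what a plain cyclopentyl group without its carbamoyl part, or a longer chain carrying the same tert-butyl amide, would give.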